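The source may hold more compounds than are shown below. What is called first, only, known or untested is meant among the compounds shown, and "the series" means these compounds.

Series in a functional assay on the whole organism with Mus musculus as the target, in the rotarod test; a lower number here means that less compound is needed, a higher number that more compound is needed for the effect:
- compound 1 `CCCCCC(=O)NCC(=O)N(C)c1ccc(Cl)cc1C(=O)c1ccccc1Cl`: 90 mg/kg
- compound 2 `CC(=O)NCC(=O)N(C)c1ccc(Cl)cc1C(=O)c1ccccc1Cl`: 58 mg/kg
- compound 3 `CN1CCN(CC(=O)NCC(=O)N(C)c2ccc(Cl)cc2C(=O)c2ccccc2Cl)CC1`: not yet measured

Compound 2, at 58 mg/kg, does not stand apart from compound 1, as the two values lie within the scatter of each other. Compound 3 differs from compound 2 by 4-methylpiperazin-1-yl in place of hydrogen on a saturated chain carbon bound to a carbonyl carbon. Among the compounds with values here, one measured step bears on this place: a 1.6-fold lower number from compound 1 to compound 2 (0.19 log units; within the scatter), where hydrogen replaces butyl. Within the data shown here, it offers only limited guidance, since no measured compound carries a ring there. No change beyond the scatter is therefore expected in this assay, and no direction can be assigned with confidence. The expected change is a 1.2-fold higher number from compound 2 to compound 3 (0.08 log units; within the scatter). Compound 3 is estimated at 70 mg/kg, with an expected range of 30 mg/kg to 170 mg/kg.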

Compound 3, dose for half-maximal effect: > 100 mg/kg
Compound 3 ended at the assay's limit; the forecaster's own chance of this, stated with the estimate: 10%; at least 1.4-fold (0.15 log units) between middle value and limit.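

In this assay, compound 3 stands at a limit of the assay and not at a number: the limit of > 100 mg/kg in this assay, at which 1 of the 3 values shown sits. Within the data shown here, for the first time, a group with a ring sits on the saturated chain carbon bound to a carbonyl carbon, and the result reads as an at least 1.7-fold higher number from compound 2 to compound 3 (0.23 log units; that floor lies within the scatter) and as an at least 1.1-fold higher number from compound 1 to compound 3 (0.04 log units; that floor lies within the scatter). From the compounds shown here alone, the direction of both steps is therefore settled, with 4-methylpiperazin-1-yl giving no lower number than hydrogen or butyl, but both floors lie within the scatter, so their size remains unknown.

Going by these compounds, how far the true value of compound 3 lies past the limit remains open. On these data alone, it is also open whether the ring or its nitrogen atoms govern the result, a question that piperidin-1-yl, morpholin-4-yl or an open-chain dimethylamino group at this place could help separate.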